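A change on the carbonyl of compound 3

A few compounds are considered here, and "the series" means these few. Any claim that something is new, unique, unknown or untested is made for them only; others in the source may bear on it.

Compound 1 (`C=CC(=O)NCC1CCN(S(=O)(=O)c2ccc(NC(=O)OCc3ccccc3)cc2)CC1`): > 6 h (a limit)
Compound 2 (`C=CC(=O)N[C@@H]1CCCN(S(=O)(=O)c2ccc(NC(=O)OCc3ccccc3)cc2)C1`): > 6 h (a limit)
Compound 3 (`C=CC(=O)NC1CCN(S(=O)(=O)c2ccc(C(=O)NCCCc3ccccc3)cc2)CC1`): > 6 h (a limit)

All three compounds were tested in an ADME assay on a cell-free system (plasma, Mus musculus) for metabolic stability, tested at 1 uM (on this read-out higher numbers stand for a longer-lived compound and lower numbers for a shorter-lived compound), and none of them has an exact number there. In this assay compound 3 gives > 6 h as its reading, and this is a limit of the assay and not a number. Within the data shown here, the whole set stands at the limit of > 6 h in this assay, at which 3 of the 3 values shown sit, so no measured step is available to guide the next compound.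

Compound 4 (`C=CC(=O)NC1CCN(S(=O)(=O)c2ccc(C(=O)N(C)Cc3ccccc3)cc2)CC1`) has benzyl(methyl)amino in place of (3-phenylpropyl)amino on a carbonyl carbon. Compound 1 and compound 2 reach the same limit as compound 3, although their structures differ from it. No change beyond the usual scatter is expected, in either direction, and the expected step that the limit leaves unreadable from compound 3 to compound 4 is small. For compound 4 the estimate is 8 h, with an expected range from 4 h to 20 h, and the assay is expected to report only a limit again.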

Compound 4, half-life: > 6 h
Compound 4: only a limit was reported (the forecaster's own chance of this, stated with the estimate: 85%); the middle value lies beyond the limit too.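

No step can be read from compound 3 to compound 4, since both give a limit and not a number in this assay: the limit of > 6 h in this assay, at which 4 of the 4 values shown sit.

The compounds shown leave open whether benzyl(methyl)amino in place of (3-phenylpropyl)amino on a carbonyl carbon changes the half-life at all, and which of the four compounds, if any, is longer-lived.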